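The source may hold more compounds than are shown below. What is called first, only, known or untested is meant among the compounds shown, and "the series" means these compounds.

Measured so far in a functional assay on MGC-803 cells (Homo sapiens) for inhibition, read by MTT assay, with a stated time of 72 h; a higher number here means a weaker inhibitor, a lower number a stronger inhibitor:
- compound 1 `FC(F)(F)c1ccc(CSc2nc(N3CCNCC3)cc(C(F)(F)F)n2)cc1` gives 5870 nM
- compound 2 `CN1CCN(c2cc(C(F)(F)F)nc(SCc3ccc(C(F)(F)F)cc3)n2)CC1` gives 15800 nM

Compound 2 holds the higher of the two numbers and is therefore the weaker inhibitor of the pair. The next step leads to compound 3 `FC(F)(F)c1ccc(CSc2nc(N3CCN(c4ccccc4)CC3)cc(C(F)(F)F)n2)cc1` with this change (phenyl in place of methyl on an amine nitrogen in a ring), phenyl in place of methyl on an amine nitrogen in a ring. Among the measured compounds shown here, one measured step bears on it (a 2.7-fold higher number from compound 1 to compound 2 (0.43 log units; beyond the scatter)), a modest one, with methyl in place of hydrogen on the same nitrogen. For the measured compounds named here, that single step gives no direction for phenyl, and no measured compound carries a ring at this nitrogen. No step beyond the scatter is therefore expected in this assay. The estimated step is small (a 1.3-fold lower number from compound 2 to compound 3 (0.12 log units; within the scatter)), with wide uncertainty. The expected value for compound 3 is 12000 nM (estimated range 4000 nM to 35000 nM).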

Compound 3, half-maximal inhibitory concentration: 35200 nM
For compound 3 the middle estimate is 2.9-fold (0.47 log units) below the measured one; the whole stated range lies below it.
By their numbers in this assay, from the lowest: compound 1; then compound 2; then compound 3.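

In this assay, a 2.2-fold higher number from compound 2 to compound 3 (0.35 log units; beyond the scatter) shows that the number keeps rising when the group on this amine nitrogen grows from methyl to phenyl, so a six-membered aromatic ring of carbon only does not recover what methyl lost. Over the whole change, a 6.0-fold higher number from compound 1 to compound 3 (0.78 log units; beyond the scatter) is the largest step so far at this position, and the three compounds now run in the order hydrogen, methyl, phenyl, with none going against it. No measurement at hand explains this order.

As far as these compounds go, whether a benzyl group, an ethyl chain or an acetyl group on this nitrogen would fit the same order remains open. From the compounds shown here alone, all three compounds share the rest of the structure, so it is also open whether the order would hold with a chlorine in place of the trifluoromethyl on the benzene ring.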